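Urea in place of a bromobenzamide on a shared core

This account rests on a few compounds, and the source may have more. Where it says the series, first, only, none or still open, it means among the compounds named here.

Of the compounds shown here, three have been measured in an assay on isolated protein for inhibition of vascular endothelial growth factor receptor 2 (Danio rerio), read by fluorescence and microscopy, with a stated time of 33 h; a lower number here means a stronger inhibitor, a higher number a weaker inhibitor. Compound 1 `Cn1ncc2c(Oc3ccc(NC(=O)Nc4ccc(C(F)(F)F)cc4)cc3)ncnc21` reaches only the limit of the assay, > 100000 nM, and no number. Compound 2 `O=C(Nc1ccc(C(F)(F)F)cc1)Nc1cccc(Oc2ncnc3[nH]ncc23)c1` likewise stops at the limit, > 100000 nM. Within the data shown here, compound 3 `O=C(Nc1ccc(Oc2ncnc3[nH]ncc23)cc1)c1ccc(Br)cc1` is the one member of the set that gives a number in this assay, 74700 nM, so it stands as the only measured value, the two other results sitting at the limit of > 100000 nM in this assay, at which 2 of the 3 values shown sit.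

Compound 4 `O=C(Nc1ccc(Oc2ncnc3[nH]ncc23)cc1)Nc1cccc(F)c1` shares the core of compound 3 and differs from it at one place only: (3-fluorophenyl)amino in place of 4-bromophenyl on a carbonyl carbon. Among the measured compounds shown here, no measured pair shows what such a change does here. Compound 1 and compound 2 carry an amide-type nitrogen on the carbonyl carbon too and both remained at the limit of this assay, which gives no ground to expect a gain. The author therefore expects the step of a 1.2-fold higher number from compound 3 to compound 4 (0.08 log units; within the scatter) to be small and, if anything, towards a weaker inhibitor, with a fair chance that only a limit is reported. Compound 4 is estimated at 90000 nM, between 20000 nM and 400000 nM in this assay.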

Compound 4, half-maximal inhibitory concentration: 16600 nM
Estimate against measurement, compound 4: 5.4-fold (0.73 log units) above; measured number outside the range, below it.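

In this assay, putting (3-fluorophenyl)amino in place of 4-bromophenyl on a carbonyl carbon gives a 4.5-fold lower number from compound 3 to compound 4 (0.65 log units; beyond the scatter), a modest step that lies beyond the scatter and the only step between measured compounds shown here. It shows that this position responds to a change of group, and that a nitrogen-bearing group in this place is compatible with a measurable number on the shared core, which the earlier results could not show. Compounds 1 and 2 also carry a nitrogen on the carbonyl carbon, but each differs from compound 4 in more than one place and each result is a limit, so neither can be set against this step: the limit of > 100000 nM in this assay, at which 2 of the 4 values shown sit.

The step changes several things at once, as the entering group brings a nitrogen with a hydrogen-bond donor and a fluorine, while the bromine leaves, so the compounds shown do not assign the lower number to any one of these. From the compounds shown here alone, a plain phenylamino group or a (4-bromophenyl)amino group on the same carbonyl carbon would bear on that question, and the effect of a chlorine or a methoxy group on the ring also remains open.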